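The source may report more compounds than this note shows. Statements on the series, on what has been measured and on what is new or still open speak of the compounds shown alone.

In a physicochemical assay for metabolic stability, read by HPLC (on this read-out lower numbers stand for a shorter-lived compound and higher numbers for a longer-lived compound), compound 1 `O=c1ccn([C@H]2CC[C@@H](COP(=O)(O)Oc3cccnc3)O2)c(=O)[nH]1` gives 50.2 h and compound 2 `Cc1cn([C@H]2C[C@H](N=[N+]=[N-])[C@@H](COP(=O)(O)Oc3ccc(C#N)cc3)O2)c(=O)[nH]c1=O` gives 7.08 h, so compound 2 holds the lower of the two numbers, with a gap beyond the scatter. Compound 3 `Cc1cn([C@H]2C[C@H](N=[N+]=[N-])[C@@H](COP(=O)(O)Oc3ccc(Cl)cc3Cl)O2)c(=O)[nH]c1=O` differs from compound 2 in one place, with 2,4-dichlorophenyl in place of 4-cyanophenyl on an oxygen. Within the data shown here, no measured pair shows this change in this assay, so the expectation rests on the structural change alone. The expected step is a 1.1-fold higher number from compound 2 to compound 3 (0.05 log units; within the scatter), none beyond the scatter. For compound 3 the estimated half-life is 8 h, with an expected range from 3.5 h to 16 h.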

Compound 3, half-life: 3.03 h
For compound 3 the middle estimate is 2.6-fold (0.42 log units) above the measured one, and the stated range ends above it.
By their numbers in this assay, from the lowest: compound 3; then compound 2; then compound 1.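

In this assay, 2,4-dichlorophenyl in place of 4-cyanophenyl on the oxygen bound to phosphorus gives a 2.3-fold lower number from compound 2 to compound 3 (0.37 log units; beyond the scatter) on otherwise identical structures. The half-life therefore responds to the group at this position, even though the two groups have the same heavy-atom count and each carries one six-membered aromatic ring of carbon only.

Going by these compounds, the two compounds do not separate loss of the nitrile from entry of the chlorines, and the reading for a plain phenyl or a methoxyphenyl group on this oxygen remains open. No available measurement accounts for the step.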